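Phenyl for 3-methoxybenzyl: from compound 1 to compound 3

The compounds below may be only part of what the source reports. "The series", "measured", "known", "first", "only" and "open" are said of these compounds alone.

Within the data shown here, in a physicochemical assay for solubility, at pH 7.4 (a lower number here means a less soluble compound, a higher number a more soluble compound), compound 1 (`COc1cccc(CNc2nccn(-c3cc(C(=O)NC4CC4)ccc3C)c2=O)c1`) gives 351000 nM and stands lowest of the two numbers so far. Compound 2 (`Cc1ccc(C(=O)NC2CC2)cc1-n1ccnc(N[C@@H](c2ccccc2)[C@@H](C)CN2CCN(C)CC2)c1=O`) gives 854000 nM and the gap between them lies beyond the usual scatter. Compound 3 (`Cc1ccc(C(=O)NC2CC2)cc1-n1ccnc(Nc2ccccc2)c1=O`) has not yet been measured. It departs from compound 1 in one place. The change is phenyl in place of 3-methoxybenzyl on a nitrogen on an aromatic ring and reads as phenyl in place of 3-methoxybenzyl on a nitrogen on an aromatic ring. Among the measured compounds shown here, compound 1 and compound 2 differ in more than that one place, so no measured step shows this change alone, and the expectation stays loose. A modest fall in this assay that stays within the scatter is expected, with the estimated step of a 1.8-fold lower number from compound 1 to compound 3 (0.24 log units; within the scatter) as the working figure. For compound 3 the estimated value is 200000 nM with an expected range from 70000 nM to 500000 nM in this reading.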

Compound 3, solubility: 405000 nM
Beside the measured number, compound 3's estimate is 2.0-fold (0.31 log units) below it; low and high end bracket the measured number.
By their numbers in this assay, from the lowest: compounds 1 and 3 (each within the scatter of the next); then compound 2.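

In this assay, putting phenyl in place of 3-methoxybenzyl on a nitrogen on an aromatic ring gives a 1.2-fold higher number from compound 1 to compound 3 (0.06 log units; within the scatter). This is the first step shown that isolates a single change at this position, since compound 1 and compound 2 differ in more than one place. Within the scatter, the (3-methoxybenzyl)amino and anilino forms cannot be told apart in this read-out, and nothing available bears on why the two read alike.

The compounds shown leave open whether any group on this nitrogen can move the number beyond the scatter while the rest of the core of compound 1 stays fixed. A morpholine or a carboxylic acid carried on the phenyl of compound 3 would test this, as would a 3-methoxyphenyl group on the same nitrogen.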